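Methanesulfonamido for 3-oxopiperazin-1-yl in compound 3

The compounds below may be only part of what the source reports. "The series", "measured", "known", "first", "only" and "open" are said of these compounds alone.

In a functional assay on blood (Homo sapiens), with a stated time of 60 min, in the presence of a further agent that is not named here (on this read-out higher numbers stand for an effect only at larger amounts of compound and lower numbers for an effect already at smaller amounts), compound 3 `O=C1CN(C(=O)C2(S(=O)(=O)c3ccc(Oc4ccc(OC(F)(F)F)cc4)cc3)CCC3(CCNCC3)C2)CCN1` gives 7500 nM and holds the higher of the two true numbers, while compound 1 `NC(=O)C1(S(=O)(=O)c2ccc(Oc3ccc(OC(F)(F)F)cc3)cc2)CCC2(CCNCC2)C1` gives 3700 nM as the lower one. Compound 2 `O=C(Nc1nccs1)C1(S(=O)(=O)c2ccc(Oc3ccc(OC(F)(F)F)cc3)cc2)CCC2(CCNCC2)C1` gives > 15000 nM as a limit of the assay, not a number. The change leading to compound 4 `CS(=O)(=O)NC(=O)C1(S(=O)(=O)c2ccc(Oc3ccc(OC(F)(F)F)cc3)cc2)CCC2(CCNCC2)C1` is methanesulfonamido in place of 3-oxopiperazin-1-yl on a carbonyl carbon and keeps the shared core. Two measured steps replace the amino group on that carbonyl carbon, a 2.0-fold higher number from compound 1 to compound 3 (0.31 log units; beyond the scatter) and an at least 4.0-fold higher number from compound 1 to compound 2 (0.60 log units; beyond the scatter) against a limit, and both go toward higher numbers. Compound 4 also lacks that amino group, so a high number is expected to persist. The expected step is a 1.1-fold higher number from compound 3 to compound 4 (0.03 log units; within the scatter) in this assay and stays within the scatter. The estimate for compound 4 is 8000 nM with 3000 nM to 15000 nM as its expected range.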

Compound 4, half-maximal effective concentration: > 15000 nM
Compound 4: a limit, no number; the forecaster's own chance of this, stated with the estimate: 30%; middle value at least 1.8-fold (0.27 log units) away from the limit.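

In this assay compound 4 gives > 15000 nM, a limit of the assay and not a number. Methylsulfonyl on the amide-type nitrogen gives an at least 4.0-fold higher number from compound 1 to compound 4 (0.60 log units; beyond the scatter), and methanesulfonamido on the carbonyl carbon gives an at least 2.0-fold higher number from compound 3 to compound 4 (0.30 log units; that floor lies within the scatter), so a second substituent on that nitrogen, after the 1,3-thiazol-2-yl of compound 2, again reaches the limit. The step between compound 2 and compound 4 cannot be read: the limit of > 15000 nM in this assay, at which 2 of the 4 values shown sit.

From the compounds shown here alone, how far compound 2 and compound 4 truly lie past that limit stays open. So does how a carboxylic acid or a methylamino group on that carbonyl carbon would compare with the amino group of compound 1.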